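Propyl to Cyclobutyl on a Ring Nitrogen: Expected Binding

The source may hold more compounds than are shown below. What is called first, only, known or untested is meant among the compounds shown, and "the series" means these compounds.

Of the compounds shown here, three sharing one core have been measured in an assay on HeLa cells for displacement of a labelled ligand from 5-hydroxytryptamine receptor 6 (Homo sapiens); a higher number here means a weaker inhibitor, a lower number a stronger inhibitor. Compound 1 `O=S(=O)(c1cccc2ccccc12)c1cccc2oc(N3CCNCC3)nc12` gives 3.1 nM, compound 2 `O=S(=O)(c1ccc2oc(N3CCNCC3)nc2c1)c1cccc2ccccc12` gives 52 nM, and compound 3 `CCCN1CCN(c2nc3c(S(=O)(=O)c4cccc5ccccc45)cccc3o2)CC1` gives 36 nM. Among these, compound 3 holds the second highest number; its nearest neighbour is compound 2, within the scatter, while compound 1 lies furthest from it, beyond the scatter. For the measured compounds named here, the only step between measured compounds that differ in one place is a 12-fold higher number from compound 1 to compound 3 (1.06 log units; beyond the scatter).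

Compound 4 `O=S(=O)(c1cccc2ccccc12)c1cccc2oc(N3CCN(C4CCC4)CC3)nc12` has not yet been measured. It differs from compound 3 in one place: cyclobutyl in place of propyl on an amine nitrogen in a ring. Going by the values given here, no measured pair shows this exchange of one carbon-only group for another on that ring nitrogen; the step that bears on the site is a 12-fold higher number from compound 1 to compound 3 (1.06 log units; beyond the scatter), which concerns placing propyl on an unsubstituted nitrogen. Because compound 3 already carries propyl there with 36 nM, and cyclobutyl is again a carbon-only group with no donors or acceptors, the step from compound 3 to compound 4 is expected to be a 1.2-fold lower number from compound 3 to compound 4 (0.08 log units; within the scatter), that is, none beyond the scatter. Compound 4 is therefore estimated at 30 nM, with a range from 8 nM to 120 nM.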

Compound 4, inhibition constant: 72 nM
Beside the measured number, compound 4's estimate is 2.4-fold (0.38 log units) below it, and the stated range covers the measured number.
By their numbers in this assay, from the lowest: compound 1; then compounds 3, 2 and 4 (each within the scatter of the next).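

At this position, on an amine nitrogen in a ring, closing the carbon group into a four-membered ring makes no difference that can be told from the scatter in this assay: the exchange gives a 2.0-fold higher number from compound 3 to compound 4 (0.30 log units; within the scatter). The cost of substitution seen earlier with propyl now appears with a second carbon-only group, as cyclobutyl gives a 23-fold higher number from compound 1 to compound 4 (1.37 log units; beyond the scatter), so both substituted compounds lie beyond the scatter from the free nitrogen of compound 1, and neither of the two listed compounds goes against this. Nothing available explains why either group on this nitrogen gives a higher number than hydrogen, or what the ring in cyclobutyl does or does not contribute.

The compounds shown leave open whether this holds for methyl, for a longer chain such as butyl, or for a group that is not carbon-only, such as 2-hydroxyethyl or a chain ending in an amine. They also leave open whether propyl or cyclobutyl on the ring nitrogen of compound 2 would give a step like those seen from compound 1.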